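The source may report more compounds than this note shows. Statements on the series, on what has been measured and on what is new or still open speak of the compounds shown alone.

Measured so far:
- compound 1 `O=c1ccc2cc(OCc3cn(-c4cccc(CO)c4)nn3)ccc2o1` — "not determined" (no result reported)
- compound 2 `O=c1ccc2cc(OCc3cn(-c4ccc(Cl)c(Cl)c4)nn3)ccc2o1` — 47800 nM
- compound 3 `O=c1ccc2cc(OCc3cn(-c4ccccc4[N+](=O)[O-])nn3)ccc2o1` — 44600 nM

Three compounds share one core and differ only in the aryl group attached to an aromatic nitrogen. In a functional assay on HL-60 cells (Homo sapiens) for cytotoxicity, read by MTT assay, with a stated time of 48 h (on this read-out lower numbers stand for stronger inhibition and higher numbers for weaker inhibition), compound 1 gave no result. In this assay compound 2 gives 47800 nM and compound 3 gives 44600 nM. Within the data shown here, the only measured step, a 1.1-fold lower number from compound 2 to compound 3 (0.03 log units; within the scatter), stays within the scatter, so compounds 2 and 3 cannot be told apart on these numbers, and compound 3 simply stands beside compound 2 in the weak range.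

Compound 4 `N#Cc1ccccc1-n1cc(COc2ccc3oc(=O)ccc3c2)nn1` carries the change (cyano in place of nitro on an aromatic carbon). Among the measured compounds shown here, the single step that bears on it, a 1.1-fold lower number from compound 2 to compound 3 (0.03 log units; within the scatter), swapped a whole aryl group at the same region without moving the number beyond the scatter; a smaller swap of one substituent on that same ring is therefore expected to leave the number about where compound 3 sits, with no step beyond the scatter in either direction. For compound 4 the expected step is a 1.0-fold higher number from compound 3 to compound 4 (0.00 log units; within the scatter). Compound 4 is estimated at 45000 nM, with a range from 15000 nM to 130000 nM.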

Compound 4, half-maximal inhibitory concentration: 52100 nM
The estimate for compound 4 lay 1.2-fold (0.06 log units) below the measured number, and the stated range covers the measured number.
By their numbers in this assay, from the lowest: compounds 3, 2 and 4 (each within the scatter of the next).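

In this assay the swap of nitro for cyano on the aromatic carbon ortho to a large group gives a 1.2-fold higher number from compound 3 to compound 4 (0.07 log units; within the scatter) and so does not separate the two compounds, which shows that this single substituent exchange leaves the number within the scatter. The 2-cyanophenyl group also cannot be told apart from the 3,4-dichlorophenyl group, with a 1.1-fold higher number from compound 2 to compound 4 (0.04 log units; within the scatter) on that comparison, so compounds 2, 3 and 4 all remain together in the weak range. Nothing measured here offers a reason why these groups read alike.

On these data alone, whether an amine or a carboxylic acid at this place would move the number beyond the scatter stays open. The same question stands for a methoxy group or a longer chain on this ring.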